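Chloro to trifluoromethyl on the benzoyl ring of compound 1

This account rests on a few compounds, and the source may have more. Where it says the series, first, only, none or still open, it means among the compounds named here.

Measured so far:
compound 1, `COc1cc2ncnc(NNC(=S)NC(=O)c3ccc(Cl)cc3)c2cc1OC`, 7530 nM
compound 2, `O=C(NC(=S)NNc1ncnc2ccccc12)c1ccc(Cl)cc1`, 1530 nM

In a functional assay on CNE-2 cells (Homo sapiens) for cytotoxicity, read by MTT assay, with a stated time of 72 h (on this read-out higher numbers stand for weaker inhibition and lower numbers for stronger inhibition), compound 1 gives 7530 nM, the higher of the two numbers recorded so far. Compound 2 gives 1530 nM in this assay; the two compounds differ in more than one place, so nothing is drawn from that gap beyond what the two values show. Compound 3 `COc1cc2ncnc(NNC(=S)NC(=O)c3ccc(C(F)(F)F)cc3)c2cc1OC` is not yet measured. It differs from compound 1 in one place: trifluoromethyl in place of chloro on an aromatic carbon. Among the compounds with values here, no measured pair in this set carries this exchange, so its size in this assay is unknown. Compound 3 is expected to sit close to compound 1, with a step from compound 1 to compound 3 of a 1.1-fold lower number from compound 1 to compound 3 (0.03 log units; within the scatter) expected, no direction beyond the usual scatter. Compound 3 is estimated at 7000 nM, expected to fall between 2500 nM and 20000 nM.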

Compound 3, half-maximal inhibitory concentration: 16500 nM
Estimate against measurement, compound 3: 2.4-fold (0.37 log units) below; the range from low to high includes it.
By their numbers in this assay, from the lowest: compound 2; then compound 1; then compound 3.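

Of the compounds shown, this is the first comparison that isolates a single place, and it shows that this aromatic carbon, para to a large group, is sensitive to its substituent. In this assay, the exchange of chloro for trifluoromethyl gives a 2.2-fold higher number from compound 1 to compound 3 (0.34 log units; beyond the scatter), a modest step toward weaker inhibition, so chloro is the better of the two groups at this place on the core of compound 1. No measurement bears on what lies behind this step.

Within the data shown here, with only two groups compared at this carbon, it remains open whether fluoro, a nitrile or an amine would give stronger or weaker inhibition than chloro. From the compounds shown here alone, whether the same exchange has a similar effect on the core of compound 2 also remains open.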